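Lengthening the Sulfamoylamino Linker on a Shared Core

This account rests on a few compounds, and the source may have more. Where it says the series, first, only, none or still open, it means among the compounds named here.

Of the compounds shown here, two sharing a common core have been measured. Compound 1 `COc1ccc(-c2cc(N3CCC(CNS(N)(=O)=O)CC3)ncn2)cc1` and compound 2 `CCOC(=O)c1ccc(-c2cc(N3CCC(CNS(N)(=O)=O)CC3)ncn2)cc1` differ only in the group on the aromatic ring. In a functional assay on M21 cells (Homo sapiens) for antiproliferative activity, read by sulforhodamine B assay, with a stated time of 48 h (on this read-out lower numbers stand for stronger inhibition of growth and higher numbers for weaker inhibition of growth), compound 1 reaches only the limit of the assay, > 100000 nM. Compound 2 gives 5000 nM in this assay. For the measured compounds named here, the one step measured, an at least 20-fold lower number from compound 1 to compound 2 (1.30 log units; beyond the scatter), therefore carries a caveat: it is counted from the limit of > 100000 nM in this assay, at which 1 of the 2 values shown sits, so its true size is not known.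

Compound 3 `COc1ccc(-c2cc(N3CCC(CCNS(N)(=O)=O)CC3)ncn2)cc1` has not yet been measured. It differs from compound 1 by (sulfamoylamino)methyl in place of sulfamoylamino on a saturated chain carbon bound to a saturated ring carbon. Going by the values given here, no measured step touches this part of the molecule; the single measured step concerns the aromatic substituent and offers no guidance on the chain. With compound 1 resting at a limit and nothing measured about the chain, the expectation for compound 3 is no step beyond the scatter, a number no higher from compound 1 to compound 3 (the limit leaves the size open), and most likely another limit rather than a number. Compound 3 is therefore estimated at 100000 nM in this assay, with a range from 30000 nM to 300000 nM.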

Compound 3, concentration for 50% growth inhibition: 69800 nM
For compound 3 the middle estimate is 1.4-fold (0.16 log units) above the measured one; the measured number falls inside the stated range.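

For the compounds shown here, compound 3 gives the first reading for a change on the chain, and in this assay compound 3 gives 69800 nM, a number rather than a limit. With (sulfamoylamino)methyl in place of sulfamoylamino on a saturated chain carbon bound to a saturated ring carbon, the data show an at least 1.4-fold lower number from compound 1 to compound 3 (0.15 log units; that floor lies within the scatter), so the lengthened chain brings the methoxy compound into the measurable range without showing a gain beyond the scatter. How large the step truly is cannot be said, and it may be either small or much larger: the limit of > 100000 nM in this assay, at which 1 of the 3 values shown sits.

The compounds shown leave open whether the ethoxycarbonyl group of compound 2 and the 2-(sulfamoylamino)ethyl chain of compound 3 would add up when carried by one molecule, and what a still longer chain, such as 3-(sulfamoylamino)propyl, would give on the shared core. They also leave open how an amine or a carboxylic acid would read in place of the sulfamoylamino end of the chain.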